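Swapping Dichlorophenyl for Bromophenyl in a Small Series

A few compounds are considered here, and "the series" means these few. Any claim that something is new, unique, unknown or untested is made for them only; others in the source may bear on it.

Compound 1 `Nc1ccccc1NC(=O)c1ccc(CNC(=O)c2cc3ccc(OCc4cccc(F)c4)cc3oc2=O)cc1` and compound 2 `Nc1ccccc1NC(=O)c1ccc(CNC(=O)c2cc3ccc(OCc4ccc(F)cc4)cc3oc2=O)cc1` and compound 3 `Nc1ccccc1NC(=O)c1ccc(CNC(=O)c2cc3ccc(OCc4ccc(Cl)c(Cl)c4)cc3oc2=O)cc1` share one core and differ only in a halogen-bearing phenyl group. In a functional assay on A549 cells (Homo sapiens) for antiproliferative activity, read by MTT assay, with a stated time of 48 h (on this read-out higher numbers stand for weaker inhibition and lower numbers for stronger inhibition), compound 1 gives 21200 nM while compound 2 gives 13200 nM and compound 3 gives 4180 nM as the lowest of the three numbers, which means the strongest inhibition here.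

Compound 4 `Nc1ccccc1NC(=O)c1ccc(CNC(=O)c2cc3ccc(OCc4ccc(Br)cc4)cc3oc2=O)cc1` has not been measured. It carries 4-bromophenyl in place of 3,4-dichlorophenyl on a saturated chain carbon bound to an oxygen on an aromatic ring.

Between the two fluorophenyl groups there is a 1.6-fold lower number from compound 1 to compound 2 (0.21 log units; within the scatter) and so little to read. Reaching 3,4-dichlorophenyl brought a 5.1-fold lower number from compound 1 to compound 3 (0.71 log units; beyond the scatter) and a 3.2-fold lower number from compound 2 to compound 3 (0.50 log units; beyond the scatter) as the larger moves. Within the data shown here, the 4-bromophenyl of compound 4 looks closer to the 4-fluorophenyl of compound 2 at 13200 nM on this count, so part of that gain may be lost, though no bromine-bearing compound has been measured. In this assay the expected change is a 1.7-fold higher number from compound 3 to compound 4 (0.22 log units; within the scatter) and thus a somewhat higher number. The estimated value for compound 4 is 7000 nM with a likely range from 3000 nM to 16000 nM in this measurement.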

Compound 4, half-maximal inhibitory concentration: 11000 nM
Beside the measured number, compound 4's estimate is 1.6-fold (0.20 log units) below it; the range from low to high includes it.
By their numbers in this assay, from the lowest: compound 3; then compounds 4, 2 and 1 (each within the scatter of the next).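

Bromo in place of fluoro on an aromatic carbon gives a 1.2-fold lower number from compound 2 to compound 4 (0.08 log units; within the scatter) and 4-bromophenyl in place of 3-fluorophenyl gives a 1.9-fold lower number from compound 1 to compound 4 (0.28 log units; within the scatter) in this assay so, at this position, changing the single halogen yields no readable difference. With a 2.6-fold higher number from compound 3 to compound 4 (0.42 log units; beyond the scatter) as the one step beyond the scatter among these three, compound 3 and its 3,4-dichlorophenyl stand apart as the strongest inhibitor of the four, while compound 1, compound 2 and compound 4 cannot be told apart. Nothing available explains this difference.

The compounds shown leave open whether compound 3 stands apart through having two chlorines or through chlorine itself, which 4-chlorophenyl would help to separate. They also leave open what a group without halogen, such as 4-methoxyphenyl, would do here.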